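Swapping a Side Chain in a Tail Flick Series

The compounds below may be only part of what the source reports. "The series", "measured", "known", "first", "only" and "open" are said of these compounds alone.

Of the compounds shown here, three sharing one core have been measured in a functional assay on the whole organism (Tail, strain ICR) with Mus musculus as the target, in the tail flick test, with a stated time of 120 min, at a dose of 25 umol/kg by the oral route; on this read-out higher numbers stand for a stronger effect at the one dose given and lower numbers for a weaker effect. Compound 1 `CC[C@H](C)[C@H](NC(=O)CN(c1nc(Cl)nc2[nH]cnc12)C1CC1)C(=O)O` gives 21.4%. Compound 3 `CC[C@H](C)[C@H](NC(=O)CN(c1nc(Cl)nc2[nH]cnc12)C1CC1)C(=O)OCc1ccccc1` gives 22%, and compound 2 `C[C@@H](O)[C@H](NC(=O)CN(c1ncnc2c1ncn2C1CCCCO1)C1CC1)C(=O)OCc1ccccc1` gives 10.9%. Compound 1 therefore stands second highest of the three numbers; its nearest neighbour is compound 3, and compound 2 lies furthest from it.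

Among the compounds with values here, the only step between compounds that differ in one place is a number 0.6 percentage points higher from compound 1 to compound 3 (within the scatter), which is benzyl in place of hydrogen on an oxygen next to a carbonyl group. Compound 2 differs from compound 1 in more than one place, so its lower number cannot be tied to any single change.

Compound 4 `NCCCC[C@H](NC(=O)CN(c1nc(Cl)nc2[nH]cnc12)C1CC1)C(=O)O` has not yet been measured. It differs from compound 1 by 4-aminobutyl in place of sec-butyl on a saturated chain carbon bound to an amide-type nitrogen and a carbonyl carbon. Within the data shown here, no measured step touches this part of the molecule, and the one known step concerns a different site and stayed within the scatter. Nothing in the data therefore points to a change in either direction. The expectation for compound 4 in this assay is a step of a number 2.4 percentage points lower from compound 1 to compound 4 (within the scatter), none beyond the scatter. Compound 4 is estimated at 19%, in a range from 7% to 31%.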

Compound 4, a percentage reported as activity, at one dose (the size of the read-out at that dose, not a potency): 16.4%
Compound 4: the middle estimate sits 2.6 percentage points above what was measured, and the stated range covers the measured number.
By their numbers in this assay, from the lowest: compounds 2, 4, 1 and 3 (each within the scatter of the next, the first and the last beyond it).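

In this assay, within the data shown here, this is the first reading at the side chain itself, on a saturated chain carbon bound to an amide-type nitrogen and a carbonyl carbon: 4-aminobutyl in place of sec-butyl gives a number 5 percentage points lower from compound 1 to compound 4 (within the scatter), whereas the one earlier step concerned a different site. The swap adds a nitrogen, with one hydrogen-bond donor and one hydrogen-bond acceptor, to the side chain, and at this single dose the two compounds still cannot be told apart, so this position tolerates this particular exchange on this read-out. Nothing at hand bears on what lies behind so small a step.

As far as these compounds go, what a carboxylic acid at the end of the chain, a phenyl ring in place of the sec-butyl, or a longer chain carrying an amine would give at this position remains open, so one exchange says little about the position as a whole. Also open, from the compounds shown here alone, is whether benzyl on an oxygen next to a carbonyl group would leave the number as unchanged on the 4-aminobutyl compound as it did on the sec-butyl one.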